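Ester chain shortening in a uracil series

A few compounds are considered here, and "the series" means these few. Any claim that something is new, unique, unknown or untested is made for them only; others in the source may bear on it.

Measured compounds in an assay on cells for displacement of a labelled ligand from adenosine receptor A1 (Homo sapiens), read by radioligand binding, with a stated time of 60 min, tested at 1 uM; a higher number here means more inhibition at the concentration tested (going by the name of the read-out), a lower number less inhibition:
- compound 1 `CC1=C(C(=O)OCC(F)(F)F)C(c2ccsc2)NC(=O)N1` gives 2%
- compound 2 `CC1=C(C(=O)OCC(F)(F)F)C(c2ccoc2)NC(=O)N1` gives 13%
- compound 3 `CC1=C(C(=O)OC(C(F)(F)F)C(F)(F)F)C(c2cccs2)NC(=O)N1` gives 9%

Compound 3 differs from compound 2 and from compound 1 by amounts that lie within the usual scatter, so the three values cannot be told apart. For the measured compounds named here, the one step measured so far, a number 11 percentage points higher from compound 1 to compound 2 (beyond the scatter), changes the aromatic ring on the core, not the ester chain.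

Compound 4 `CC1=C(C(=O)OCC(F)(F)F)C(c2cccs2)NC(=O)N1` is not yet measured. It differs from compound 3 by hydrogen in place of trifluoromethyl on a saturated chain carbon bound to an oxygen next to a carbonyl group and a saturated chain carbon. Going by the values given here, no measured step touches this part of the molecule, so there is nothing to show a shift in either direction, and all values so far are low.

For compound 4 the estimate is 8%, with a range from 0% to 20%, an expected step of a number 1 percentage points lower from compound 3 to compound 4 (within the scatter) within the scatter.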

Compound 4, a percentage reported as inhibition, at one concentration (the size of the read-out at that concentration, not a potency): 3%
For compound 4 the middle estimate is 5 percentage points above the measured one; low and high end bracket the measured number.
By their numbers in this assay, from the lowest: compounds 1, 4, 3 and 2 (each within the scatter of the next, the first and the last beyond it).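

In this assay, hydrogen in place of trifluoromethyl on this saturated chain carbon gives a number 6 percentage points lower from compound 3 to compound 4 (within the scatter) and so has no effect that can be read at this position. On the saturated ring carbon, thiophen-2-yl in place of furan-3-yl gives a number 10 percentage points lower from compound 2 to compound 4 (within the scatter) and thiophen-2-yl in place of thiophen-3-yl gives a number 1 percentage points higher from compound 1 to compound 4 (within the scatter) and so neither swap can be told apart from scatter. Nothing available here offers an explanation for these results.

From the compounds shown here alone, whether a longer chain or an amine on this carbon would shift the number beyond the scatter remains open.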